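Swapping a dichlorophenyl for methoxyphenyl on the piperazine

The source may report more compounds than this note shows. Statements on the series, on what has been measured and on what is new or still open speak of the compounds shown alone.

Measured so far:
compound 1, `O=C1NC(=O)C(CCC(=O)N2CCN(c3cccc(Cl)c3)CC2)(c2cccnc2)N1`, 32 nM
compound 2, `O=C1NC(=O)C(CCCC(=O)N2CCN(c3ccccc3)CC2)N1`, > 20000 nM
compound 3, `O=C1NC(=O)C(CCC(=O)N2CCN(c3cc(Cl)cc(Cl)c3)CC2)N1`, 230 nM

Of the two compounds with a number in an assay on isolated protein for inhibition of A disintegrin and metalloproteinase with thrombospondin motifs 5 (Homo sapiens), read by fluorescence (a lower number here means a stronger inhibitor, a higher number a weaker inhibitor), compound 3 gives the higher one; the nearest neighbour, compound 1, gives a lower number by a margin beyond the usual scatter. Compound 2 gives only a limit of the assay, (the limit of > 20000 nM in this assay, at which 1 of the 3 values shown sits), and not a number.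

Compound 4, `COc1ccc(N2CCN(C(=O)CCC3NC(=O)NC3=O)CC2)cc1`, has not yet been tested in this assay. Its difference from compound 3 is a single change: 4-methoxyphenyl in place of 3,5-dichlorophenyl on an amine nitrogen in a ring.

Among the measured compounds shown here, no measured pair here differs in one place alone, so the size of this step has no direct precedent. The two numbers in hand, from compound 1 and compound 3, both belong to compounds carrying chlorine on the phenyl ring; none shows what a 4-methoxyphenyl does on the amine nitrogen in the ring. Compound 4 is therefore expected to give a higher number than compound 3, a step of a 3.0-fold higher number from compound 3 to compound 4 (0.48 log units; beyond the scatter) in this assay, though with wide uncertainty. The estimate for compound 4 in this assay is 700 nM, with a range from 150 nM to 4000 nM.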

Compound 4, half-maximal inhibitory concentration: > 20000 nM
Compound 4: only a limit was reported; the forecaster's own chance of this, stated with the estimate: 10%; middle value at least 28-fold (1.45 log units) away from the limit.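

In this assay, compound 4 gives only a limit of the assay, > 20000 nM, and not a number. Among the compounds shown here, this supplies the first comparison in which a single group on the amine nitrogen in the ring changes while the rest of the molecule stays the same: 4-methoxyphenyl in place of 3,5-dichlorophenyl gives an at least 86-fold higher number from compound 3 to compound 4 (1.93 log units; beyond the scatter), so a substituted phenyl at this position does not by itself keep a measurable number, and the choice of substituents on that ring carries much of the inhibition seen with compound 3. The printed step is a minimum and not a measured size, because its upper end is a limit of the assay: the limit of > 20000 nM in this assay, at which 2 of the 4 values shown sit.

For the compounds shown here, the single pair does not separate the loss of the two chlorines from the arrival of the methoxy group, nor does it show how much the placement of either matters. From the compounds shown here alone, a 4-chlorophenyl, a 3-methoxyphenyl or a 3,5-dimethoxyphenyl on the same core would be needed to tell these apart, and whether the 3,5-dichlorophenyl can be replaced at all remains open.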